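The source may hold more compounds than are shown below. What is called first, only, known or untested is meant among the compounds shown, and "the series" means these compounds.

Measured so far in an ADME assay on MDCK cells (Canis lupus familiaris) for permeability, read by LC-MS, with a stated time of 90 min, tested at 2 uM; a higher number here means that the compound crosses the layer faster, a lower number that the compound crosses the layer more slowly:
- compound 1 `Cc1cc(C)c(CN2CCc3c(Cl)cc([C@@H](CO)[C@@H]4CCCO4)c(Cl)c3C2=O)c(=O)[nH]1`: 4.3 10^-6 cm/s
- compound 2 `COC(c1cc(Cl)c2c(c1Cl)C(=O)N(Cc1c(C)cc(C)[nH]c1=O)CC2)C1CCN(C(C)=O)CC1`: 11.5 10^-6 cm/s; 8.1 10^-6 cm/s (2 entries)
- compound 3 `COc1cc(C)[nH]c(=O)c1CN1CCc2c(Cl)cc([C@H](O)C3COC3)c(Cl)c2C1=O`: 0.7 10^-6 cm/s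

Compound 1 holds the higher of the two single numbers in this assay; compound 3 sits below it, and that gap lies beyond the scatter. Compound 2 has several entries rather than one number, (the several entries of compound 2 in this assay, 11.5 10^-6 cm/s; 8.1 10^-6 cm/s (2 entries)), and its spread shows how far repeats of this assay can wander.

Compound 4 `Cc1cc(C)c(CN2CCc3c(Cl)cc([C@H](CO)[C@H]4CCOC4)c(Cl)c3C2=O)c(=O)[nH]1` differs from compound 1 only in how the same atoms are joined: a group of 8 heavy atoms (6 carbon, 2 oxygen; one five-membered non-aromatic ring with 1 hetero atom) in place of a group of 8 heavy atoms (6 carbon, 2 oxygen; one five-membered non-aromatic ring with 1 hetero atom), on an aromatic carbon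

Within the data shown here, no measured step of this kind is available. With the same atoms, the same donor and acceptor count and the same ring size on each side, no step beyond the scatter is expected in this assay. Compound 4 is thus estimated at 4.5 10^-6 cm/s, range 2.2 10^-6 cm/s to 9 10^-6 cm/s, meaning an expected step of a 1.0-fold higher number from compound 1 to compound 4 (0.02 log units; within the scatter).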

Compound 4, apparent permeability: 2.9 10^-6 cm/s
Beside the measured number, compound 4's estimate is 1.6-fold (0.19 log units) above it; the range from low to high includes it.
By their numbers in this assay, from the lowest: compound 3; then compounds 4 and 1 (each within the scatter of the next).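

In this assay, exchanging one isomeric group for the other on the aromatic carbon gives a 1.5-fold lower number from compound 1 to compound 4 (0.17 log units; within the scatter). Among these compounds, this is the first step at this position in which the atoms stay the same, and it shows that this rearrangement of the five-membered non-aromatic ring and its side chain does not separate the two compounds. Repeat entries of a single compound also differ in this assay: the several entries of compound 2 in this assay, 11.5 10^-6 cm/s; 8.1 10^-6 cm/s (2 entries)

As far as these compounds go, whether a basic amine or a carboxylic acid on this aromatic carbon would give a step beyond the scatter remains open. This single pair also cannot separate the effect of ring attachment from that of stereochemistry.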